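The source may hold more compounds than are shown below. What is called first, only, known or untested is meant among the compounds shown, and "the series" means these compounds.

Three compounds give a first picture of the series. In an assay on isolated protein with Bile acid receptor (Homo sapiens) as the target (on this read-out lower numbers stand for an effect already at smaller amounts and higher numbers for an effect only at larger amounts of compound), compound 1 `COC(=O)/C=C/c1cccc(N(Cc2ccc(/C=C/c3c(Cl)cccc3Cl)cc2)C(=O)C(C)C)c1` gives 195 nM, the second highest of the three numbers. Compound 3 `COC(=O)/C=C/c1cccc(N(Cc2ccc(-c3cccc(C)c3)cc2)C(=O)C2CCCCC2)c1` gives 109 nM in this assay, a number within the scatter of that of compound 1. Compound 2 `COC(=O)/C=C/c1cccc(N(Cc2ccc(/C=C/c3cc(C(F)(F)F)cc(C(F)(F)F)c3)cc2)C(=O)C2CCCCC2)c1` gives 1470 nM in this assay, a number clearly higher than that of compound 1. Compound 4 `COC(=O)/C=C/c1cccc(N(Cc2ccc(-c3cc(Cl)ccc3OC)cc2)C(=O)C(C)C)c1` has not yet been measured. It differs from compound 1 in one place: 5-chloro-2-methoxyphenyl in place of 2-(2,6-dichlorophenyl)ethenyl on an aromatic carbon. Compound 3 shows that an aromatic group bound directly to the ring can still give a low number, so the step from compound 1 to compound 4 is expected to be small, a 1.0-fold higher number from compound 1 to compound 4 (0.01 log units; within the scatter), with no clear direction beyond the scatter. Compound 4 is therefore estimated at 200 nM in this assay, with a range from 70 nM to 600 nM.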

Compound 4, half-maximal effective concentration: 226 nM
For compound 4 the middle estimate is 1.1-fold (0.05 log units) below the measured one; the range from low to high includes it.
By their numbers in this assay, from the lowest: compounds 3, 1 and 4 (each within the scatter of the next, the first and the last beyond it); then compound 2.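

At this aromatic carbon, para to a large group, 5-chloro-2-methoxyphenyl takes the place of 2-(2,6-dichlorophenyl)ethenyl in this assay with little consequence (a 1.2-fold higher number from compound 1 to compound 4 (0.06 log units; within the scatter)). The double bond outside aromatic rings is thus not needed here for a number of this size, and exchanging a chlorine for a methoxy-bearing ring gives no clear change. No measurement at hand explains this outcome. Open, as far as these compounds go, is whether an amine on this aromatic ring would keep the number, and whether a carboxylic acid in place of the methyl ester would.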